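Working notes: chlorobenzyl sulfanyl variants, 2-chloro to 4-chloro

This account rests on a few compounds, and the source may have more. Where it says the series, first, only, none or still open, it means among the compounds named here.

Two members of the series have been measured in a functional assay on HCT-116 cells (Homo sapiens) for cytotoxicity, read by MTT assay, with a stated time of 72 h; a higher number here means a weaker inhibitor, a lower number a stronger inhibitor. Compound 1 `Cc1cc(S(=O)(=O)/N=C(\N)n2nccc2-c2ccccc2)c(SCc2ccccc2C)cc1Cl` gives 16000 nM. Compound 2 `Cc1cc(S(=O)(=O)/N=C(\N)n2nccc2-c2ccccc2)c(SCc2ccccc2Cl)cc1Cl`, which carries chloro in place of methyl on an aromatic carbon, gives 18000 nM. The step of a 1.1-fold higher number from compound 1 to compound 2 (0.05 log units; within the scatter) lies within the scatter, so compound 2 holds the higher of the two numbers only nominally; nothing separates it from compound 1 beyond repeat variation.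

Compound 3 `Cc1cc(S(=O)(=O)/N=C(\N)n2nccc2-c2ccccc2)c(SCc2ccc(Cl)cc2)cc1Cl` is not yet measured. It differs from compound 2 by 4-chlorophenyl in place of 2-chlorophenyl on a saturated chain carbon bound to a sulfur, the same atoms joined differently. Going by the values given here, no measured step touches this rearrangement. Among the compounds with values here, the single step available, from compound 1 to compound 2, concerns the same benzyl ring and moved the number within the scatter, which gives no ground for expecting a shift here either. Compound 3 is therefore expected to give about 18000 nM in this assay, between 7000 nM and 45000 nM. The expected step of no change at the digits printed from compound 2 to compound 3 (within the scatter) amounts to no change beyond the scatter.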

Compound 3, half-maximal inhibitory concentration: 7000 nM
Compound 3: the middle estimate sits 2.6-fold (0.41 log units) above what was measured; the range from low to high includes it.
By their numbers in this assay, from the lowest: compound 3; then compounds 1 and 2 (each within the scatter of the next).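

In this assay, going by these compounds alone, the change from (2-chlorobenzyl)sulfanyl to (4-chlorobenzyl)sulfanyl gives a 2.6-fold lower number from compound 2 to compound 3 (0.41 log units; beyond the scatter) and is the first step in this set beyond the scatter, a modest one made with the same atoms joined differently. Against the 2-methylphenyl group on the same saturated chain carbon bound to a sulfur, 4-chlorophenyl gives a 2.3-fold lower number from compound 1 to compound 3 (0.36 log units; beyond the scatter), so compound 3 holds the lowest number of the three, while 2-methylphenyl and 2-chlorophenyl in compound 1 and compound 2 stay within the scatter of each other. Nothing at hand bears on why the number moves with this rearrangement.

Open, on these data alone, is whether the step belongs to the chloro group itself or would also appear with 4-methylphenyl on that chain carbon, which would set the 4-chlorophenyl result of compound 3 against a direct counterpart of compound 1. Also open, as far as these compounds go, is how a 4-aminophenyl or 4-carboxyphenyl group at the same place would read in this assay, and whether any such group carries the number beyond that of compound 3.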